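Cytotoxicity series: one more methoxy on compound 1

The source may report more compounds than this note shows. Statements on the series, on what has been measured and on what is new or still open speak of the compounds shown alone.

Measured so far:
compound 1, `COc1cccc([C@H](O)[C@H]2CO[C@H](c3ccc(OC)c(OC)c3)[C@@H](C/C=C/c3ccc(OC)c(OC)c3)C2)c1`, 21200 nM
compound 2, `COc1ccc(/C=C/C[C@H]2C[C@@H]([C@@H](O)c3ccccc3)CO[C@@H]2c2ccccc2)cc1`, 8300 nM
compound 3, `O=[N+]([O-])c1cccc(/C=C/C[C@H]2C[C@@H]([C@@H](O)c3ccccc3)CO[C@@H]2c2ccccc2)c1`, 7850 nM

In a functional assay on HeLa cells (Homo sapiens) for cytotoxicity, read by WST assay, with a stated time of 48 h (a lower number here means a stronger inhibitor, a higher number a weaker inhibitor), compound 1 gives the highest of the three numbers; compound 2 at 8300 nM and compound 3 at 7850 nM both sit beyond the scatter below it. Compound 4, `COc1ccc(/C=C/C[C@H]2C[C@@H]([C@@H](O)c3ccc(OC)c(OC)c3)CO[C@@H]2c2ccc(OC)c(OC)c2)cc1OC`, differs from compound 1 by methoxy in place of hydrogen on an aromatic carbon. Going by the values given here, the only measured step, a 1.1-fold lower number from compound 2 to compound 3 (0.02 log units; within the scatter), alters the aryl on the double-bonded chain and lies within the scatter; no measured step touches the aryl that carries the hydroxyl, so none bears directly on this change. With nothing to point either way, the expected step is one that stays within the scatter, a 1.2-fold lower number from compound 1 to compound 4 (0.07 log units; within the scatter). Compound 4 is therefore estimated at 18000 nM, with a range of 6000 nM to 50000 nM.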

Compound 4, half-maximal inhibitory concentration: 23800 nM
For compound 4 the middle estimate is 1.3-fold (0.12 log units) below the measured one; the range from low to high includes it.
By their numbers in this assay, from the lowest: compounds 3 and 2 (each within the scatter of the next); then compounds 1 and 4 (each within the scatter of the next).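

Going by these compounds alone, replacing hydroxy(3-methoxyphenyl)methyl with (3,4-dimethoxyphenyl)(hydroxy)methyl gives, in this assay, a 1.1-fold higher number from compound 1 to compound 4 (0.05 log units; within the scatter), the first measured step on the aryl carrying the hydroxyl. A methoxy at this aromatic carbon, ortho to a methoxy group and para to a large group, therefore leaves the number of compound 1 within the scatter. No available evidence bears on this result.

Going by these compounds, whether an amine, a carboxylic acid or a longer alkoxy chain at this carbon would shift the number remains open. Also open, on these data alone, is whether removing the neighbouring methoxy would do so.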